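A Shorter Group on the Oxygen of Compound 1

The source may report more compounds than this note shows. Statements on the series, on what has been measured and on what is new or still open speak of the compounds shown alone.

Compound 1, `CCOC(=O)CCO/N=C(/c1ccc(OC)c(OC)c1OC)c1cccc2ccccc12`: in a functional assay on MCF7 cells (Homo sapiens) for inhibition, read by sulforhodamine B assay, with a stated time of 48 h (on this read-out lower numbers stand for stronger inhibition and higher numbers for weaker inhibition), compound 1 gives > 20000 nM, which is a limit of the assay and not a number.
Compound 2, `CCOC(=O)C(C)C(O)(c1ccc(OC)c(OC)c1OC)c1cccc2ccccc12`: compound 2 gives > 20000 nM, again a limit rather than a number.
Compound 3, `COc1ccc(C(O)(Cc2ccc(F)cc2)c2cccc3ccccc23)c(OC)c1OC`: compound 3 gives 7560 nM.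

Compound 1 stands at the limit of > 20000 nM in this assay, at which 2 of the 3 values shown sit, so only a ceiling on its inhibition is known. The new compound, compound 4, `COc1ccc(/C(=N/OC(C)=O)c2cccc3ccccc23)c(OC)c1OC`, differs from it at one place: acetyl in place of 2-(ethoxycarbonyl)ethyl on an oxygen.

Among the measured compounds shown here, the single measured step, an at least 2.6-fold lower number from compound 2 to compound 3 (0.42 log units; beyond the scatter), lies in a different pair of compounds and at a different kind of position, the saturated chain carbon, not the oxygen that is altered in compound 4. It therefore gives no direct guide to the step at hand. What remains is the position of compound 1 itself: with a limit and no number, a modest shift in either direction would most likely still leave compound 4 at or near that limit.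

Compound 4 is thus expected to inhibit weakly, with an estimated value of 15000 nM, in a range from 4000 nM to 60000 nM, which would mean an expected step of an at least 1.3-fold lower number from compound 1 to compound 4 (0.12 log units; that floor lies within the scatter).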

Compound 4, half-maximal inhibitory concentration: > 20000 nM
Compound 4 was reported as a limit; the forecaster's own chance of this, stated with the estimate: 55%; middle value at least 1.3-fold (0.12 log units) away from the limit.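

In this assay compound 4 gives > 20000 nM, which is a limit of the assay and not a number. Compound 1 also stands at a limit, so no step from compound 1 to compound 4 can be read: the limit of > 20000 nM in this assay, at which 3 of the 4 values shown sit.

The compounds shown leave open how strongly compound 1 and compound 4 actually inhibit, and which of the two groups on that oxygen gives the lower number.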